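A Prenyl Chain Replaces Bromine on the Shared Core

The source may hold more compounds than are shown below. What is called first, only, known or untested is meant among the compounds shown, and "the series" means these compounds.

For the measured compounds named here, compound 1 `Fc1cccc(F)c1Cn1c(-c2c(F)cccc2F)nc2c(Br)cccc21` stands at one end of the two numbers so far in a toxicity assay on CCRF-CEM cells (Homo sapiens) for cytotoxicity; a higher number here means that more compound is tolerated, a lower number that less compound is tolerated: in this assay compound 1 gives 24.5 uM, and the only other compound, compound 2 `CNc1cccc2c1nc(-c1c(F)cccc1F)n2Cc1c(F)cccc1F`, gives 27.2 uM, which lies within the scatter of it. Going by the values given here, the one measured step between them, a 1.1-fold higher number from compound 1 to compound 2 (0.05 log units; within the scatter), exchanges a group at the same aromatic carbon of the shared core. Compound 3 `CC(C)=CCc1cccc2c1nc(-c1c(F)cccc1F)n2Cc1c(F)cccc1F` differs from compound 1 as follows: 3-methylbut-2-en-1-yl in place of bromo on an aromatic carbon. Among the compounds with values here, the step from compound 1 to compound 2 is the only measured step that bears on this position, and it stayed within the scatter, showing that at least one replacement of bromo at this carbon leaves the half-maximal toxic concentration in this assay essentially unchanged. Whether a 3-methylbut-2-en-1-yl chain behaves like methylamino there cannot be read from two compounds. With no step beyond the scatter to build on, the expected step of a 1.1-fold lower number from compound 1 to compound 3 (0.05 log units; within the scatter) is none beyond the scatter. Compound 3 is therefore estimated at 22 uM, with a range from 9 uM to 50 uM.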

Compound 3, half-maximal toxic concentration: 28.3 uM
Compound 3: middle estimate off by 1.3-fold (0.11 log units), on the low side; the range from low to high includes it.
By their numbers in this assay, from the lowest: compounds 1, 2 and 3 (each within the scatter of the next).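

In this assay, putting 3-methylbut-2-en-1-yl in place of bromo on this aromatic carbon gives a 1.2-fold higher number from compound 1 to compound 3 (0.06 log units; within the scatter) and so adds a second replacement of bromo that stays within the scatter, this time with a chain of 5 carbon atoms and a double bond outside aromatic rings. Exchanging one replacement for the other gives a 1.0-fold higher number from compound 2 to compound 3 (0.02 log units; within the scatter) and likewise stays within the scatter, so bromo, methylamino and 3-methylbut-2-en-1-yl cannot be told apart at this carbon by the half-maximal toxic concentration. Going from the 1 heavy atom of bromo to the 5 heavy atoms of the chain therefore leaves this read-out essentially unchanged, which the single earlier step could not show for a group of this size.

From the compounds shown here alone, whether a carboxylic acid, a primary amine or a longer chain at this carbon would also stay within the scatter remains open. So does whether replacing the fluorine atoms on either of the two outer aromatic rings of the shared core would leave the number as unchanged as these replacements did. No measurement among those shown explains why these three groups cannot be told apart.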